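Replacing chloro with cyano in compound 2

The source may hold more compounds than are shown below. What is called first, only, known or untested is meant among the compounds shown, and "the series" means these compounds.

Going by the values given here, in an ADME assay on microsomes from liver (Rattus norvegicus) for metabolic stability, read by HPLC, with a stated time of 10 min, tested at 3 uM (a higher number here means that more of the compound is left, a lower number that less of the compound is left), compound 2 `COc1nc(C)c(Nc2nc(Cl)cn([C@H](C)C3CC3)c2=O)cc1C` gives 55%, the higher of the two numbers so far, while compound 1 `COC[C@H](C1CC1)n1cc(Cl)nc(Nc2cc(C)c(OC)nc2C)c1=O` gives 24%. The next molecule, compound 3 `COc1nc(C)c(Nc2nc(C#N)cn([C@H](C)C3CC3)c2=O)cc1C`, has cyano in place of chloro on an aromatic carbon. Among the compounds with values here, only one measured step is available, a number 31 percentage points higher from compound 1 to compound 2 (beyond the scatter), and it is large. That step swapped methoxy for hydrogen on a saturated chain and left the chloro group untouched, so it bears only indirectly on the new change. It gives no direction for this swap, but it does show that one small edit can move this read-out a long way. No step beyond the usual scatter is therefore expected in this assay, and the estimated step is a number 2 percentage points higher from compound 2 to compound 3 (within the scatter), with wide uncertainty. For compound 3 the estimated value is 57%, within an expected range from 37% to 77%.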

Compound 3, percent of the compound remaining: 72%
Beside the measured number, compound 3's estimate is 15 percentage points below it, within the range that was stated.
By their numbers in this assay, from the lowest: compound 1; then compound 2; then compound 3.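

Both earlier compounds carry chloro on this aromatic carbon next to the ring nitrogen, so they could not show whether this position affects this assay. The change to cyano gives a number 17 percentage points higher from compound 2 to compound 3 (beyond the scatter) and shows that it does. This modest step adds a second place where a single small edit moves the read-out beyond the scatter, after the large step on the saturated chain, a number 31 percentage points higher from compound 1 to compound 2 (beyond the scatter) and the data offer no measured explanation for the gain with cyano.

Going by these compounds, only chloro and cyano appear at this carbon, so how an amine or a trifluoromethyl group would fare there remains open. Also open, on these data alone, is whether cyano would give a similar gain alongside the methoxy-bearing chain of compound 1, as it appears here only with the 1-cyclopropylethyl group.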